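A few compounds are considered here, and "the series" means these few. Any claim that something is new, unique, unknown or untested is made for them only; others in the source may bear on it.

Of the compounds shown here, two built on a shared core have been measured so far. Compound 1 `Cc1cc(O)cc(-c2nn(CC#N)cc2-c2ccnc(-c3ccc(Oc4ccccc4)cc3)c2)c1` in a functional assay on MCF7 cells (Homo sapiens) for inhibition, read by sulforhodamine B assay, with a stated time of 48 h (on this read-out lower numbers stand for higher toxicity in this test and higher numbers for lower toxicity in this test), gives 21900 nM. Compound 2 `COc1cc(C)cc(-c2nn(CC#N)cc2-c2ccnc(-c3ccc(N(C)C)cc3)c2)c1` in this assay gives only a limit, > 100000 nM, so the test reports no number for it. From the compounds shown here alone, compound 2 thus sits at the limit of > 100000 nM in this assay, at which 1 of the 2 values shown sits, and how far it truly lies from that point is unknown. Compound 3 `Cc1cc(O)cc(-c2nn(CC#N)cc2-c2ccnc(-c3ccc(N(C)C)cc3)c2)c1` has not yet been measured. It differs from compound 2 by hydrogen in place of methyl on an oxygen on an aromatic ring. Compound 1 carries the same hydroxy group and gives a number within the range of the test, but the rest of its structure also differs from compound 2, so no single step can be read between those two. For compound 3 a modest shift toward higher toxicity, an at least 1.6-fold lower number from compound 2 to compound 3 (0.22 log units; that floor lies within the scatter), is expected, though a result given only as a limit remains quite possible. The estimate for compound 3 in this assay is 60000 nM, with a range from 20000 nM to 200000 nM.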

Compound 3, concentration lethal to 50% of the cells: 69900 nM
Compound 3: the middle estimate sits 1.2-fold (0.07 log units) below what was measured, within the range that was stated.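

Replacing methoxy with hydroxy on the 3-methoxy-5-methylphenyl group brings the dimethylamino series within the range of the test, and this assay records an at least 1.4-fold lower number from compound 2 to compound 3 (0.15 log units; that floor lies within the scatter). With the hydroxy group held constant, the other changed place can now be read on its own: dimethylamino in place of phenoxy on an aromatic carbon gives a 3.2-fold higher number from compound 1 to compound 3 (0.50 log units; beyond the scatter). The true size of the methoxy to hydroxy step stays unknown because compound 2 has only a limit: the limit of > 100000 nM in this assay, at which 1 of the 3 values shown sits.

The compounds shown do not reveal whether a longer chain on that oxygen, such as ethoxy, would behave like methoxy or like hydroxy. They also leave open whether the same methoxy to hydroxy change would have a similar effect alongside phenoxy rather than dimethylamino.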